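From (pyridin-4-yl)methyl to pyrimidin-2-yl on the ring nitrogen

The source may report more compounds than this note shows. Statements on the series, on what has been measured and on what is new or still open speak of the compounds shown alone.

Measured so far:
compound 1 `COc1ccc(N2CCN(C(=S)SCc3ccc(C(=O)Nc4ccccc4N)cc3)CC2)cc1` gives 28.1%
compound 2 `Nc1ccccc1NC(=O)c1ccc(CSC(=S)N2CCN(Cc3ccncc3)CC2)cc1` gives 33.1%

Both compounds were tested in a functional assay on A-375 cells (Homo sapiens) for antiproliferative activity, read by CCK-8 assay, with a stated time of 72 h, tested at 2 uM; on this read-out higher numbers stand for a stronger effect at the one concentration tested and lower numbers for a weaker effect. Within the data shown here, compound 2 holds the higher of the two numbers, yet its only neighbour, compound 1, sits within the scatter of it: a number 5 percentage points higher from compound 1 to compound 2 (within the scatter), a step that put (pyridin-4-yl)methyl in place of 4-methoxyphenyl on an amine nitrogen in a ring. Compound 3 `Nc1ccccc1NC(=O)c1ccc(CSC(=S)N2CCN(c3ncccn3)CC2)cc1` has not yet been measured. It differs from compound 2 at that same nitrogen: pyrimidin-2-yl in place of (pyridin-4-yl)methyl on an amine nitrogen in a ring. Among the measured compounds shown here, the one measured step at this position, a number 5 percentage points higher from compound 1 to compound 2 (within the scatter), is the only one that bears on the change, and it lay within the scatter, so swapping the group on this nitrogen has so far moved the read-out little. Compound 3 is therefore expected to show no step beyond the scatter, a number 3.1 percentage points lower from compound 2 to compound 3 (within the scatter). The estimate for compound 3 is 30%, with a range from 15% to 45%.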

Compound 3, a percentage reported as inhibition, at one concentration (the size of the read-out at that concentration, not a potency): 24%
Beside the measured number, compound 3's estimate is 6 percentage points above it, within the range that was stated.
By their numbers in this assay, from the lowest: compounds 3, 1 and 2 (each within the scatter of the next).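

With compound 3, the ring nitrogen has now carried three different groups in this assay, and the new pyrimidin-2-yl case gives two further steps: a number 9.1 percentage points lower from compound 2 to compound 3 (within the scatter) and a number 4.1 percentage points lower from compound 1 to compound 3 (within the scatter). Neither step leaves the scatter, so pyrimidin-2-yl, (pyridin-4-yl)methyl and 4-methoxyphenyl cannot be told apart on this read-out, even with an aromatic ring holding two hetero atoms in place of one. Nothing shown here gives a reason for these numbers. On these data alone, whether a simple alkyl chain, a carboxylic acid on a longer chain or a primary amine at this nitrogen would move the read-out beyond the scatter remains open. As far as these compounds go, it also remains open whether these three groups would still be indistinguishable at another concentration.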